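Methyl to ethyl: a small step in the series

A few compounds are considered here, and "the series" means these few. Any claim that something is new, unique, unknown or untested is made for them only; others in the source may bear on it.

In a functional assay on SW-620 cells (Homo sapiens) for inhibition, read by MTT assay, with a stated time of 72 h (on this read-out higher numbers stand for weaker inhibition of growth and lower numbers for stronger inhibition of growth), compound 1 `Cc1cc(CN2CCN(c3c(Cl)cnc4[nH]c(-c5cnn(C)c5)nc34)CC2)no1` gives 1800 nM and compound 3 `Cc1nn(C)cc1-c1nc2c(N3CCN(Cc4ncn(C)n4)CC3)c(Cl)cnc2[nH]1` gives 3140 nM with a gap within the scatter. Compound 2 `Cc1cc(CN2CCN(c3c(Br)cnc4[nH]c(-c5csnn5)nc34)CC2)no1` gives 20000 nM which lies beyond the scatter from compound 1, so compound 1 stands with compound 3 at the stronger end of the three. Compound 4 `CCn1cc(-c2nc3c(N4CCN(Cc5cc(C)on5)CC4)c(Cl)cnc3[nH]2)cn1` carries 1-ethyl-1H-pyrazol-4-yl for 1-methyl-1H-pyrazol-4-yl through methyl in place of hydrogen on a saturated chain carbon bound to an aromatic nitrogen in the form of methyl in place of hydrogen on a saturated chain carbon bound to an aromatic nitrogen. Within the data shown here, no measured pair isolates this change, and in this assay no step beyond the scatter is expected. The expected size is a 1.1-fold higher number from compound 1 to compound 4 (0.05 log units; within the scatter) in either direction. For compound 4 the estimate is 2000 nM with an expected range from 900 nM to 4500 nM on this read-out.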

Compound 4, concentration for 50% growth inhibition: 2180 nM
For compound 4 the middle estimate is 1.1-fold (0.04 log units) below the measured one; the measured number falls inside the stated range.
By their numbers in this assay, from the lowest: compounds 1, 4 and 3 (each within the scatter of the next); then compound 2.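

Among these compounds, the first single-place pair gives a 1.2-fold higher number from compound 1 to compound 4 (0.08 log units; within the scatter) in this assay. At this position, methyl in place of hydrogen on a saturated chain carbon bound to an aromatic nitrogen therefore stays within the usual scatter, so the 1-ethyl-1H-pyrazol-4-yl and 1-methyl-1H-pyrazol-4-yl groups cannot be told apart on this read-out. Nothing on hand gives a reason for this result.

Still open, from the compounds shown here alone, is whether a longer chain such as propyl, a branched isopropyl group or a chain ending in an amine would read the same here. Going by these compounds, a carboxylic acid at this place is equally open.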